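The source may hold more compounds than are shown below. What is called first, only, known or untested is meant among the compounds shown, and "the series" means these compounds.

Compound 1 `CCCC[C@H](CCn1cncn1)c1ccccc1` serves as the starting point. Among the compounds with values here, in an ADME assay on HEp-2 cells (Homo sapiens) for cytotoxicity, read by MTT assay, with a stated time of 3 days (on this read-out higher numbers stand for lower toxicity in this test and lower numbers for higher toxicity in this test), compound 1 gives 50.2 ug/mL, the highest of the three numbers measured so far. Compound 2 `CCCC[C@H](CCn1cncn1)c1ccc(Cl)cc1` gives 20.2 ug/mL, and compound 3 `CCCC[C@H](CCn1cncn1)c1ccc(OC)cc1` gives 34.5 ug/mL. The steps from compound 1 show a 2.5-fold lower number from compound 1 to compound 2 (0.40 log units; beyond the scatter) and a 1.5-fold lower number from compound 1 to compound 3 (0.16 log units; within the scatter), while between the two substituted compounds there is a 1.7-fold higher number from compound 2 to compound 3 (0.23 log units; within the scatter).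

Compound 4 `c1ccc([C@@H](CCn2cncn2)C2CCCCC2)cc1` has not yet been measured. Relative to compound 1, the change is cyclohexyl in place of butyl on a saturated chain carbon bound to an aromatic carbon and a saturated chain carbon. Within the data shown here, none of the measured steps alters this position; all of them concern the aromatic ring, so they bear on the new change only loosely, showing that the numbers have so far moved downward from compound 1 by at most a modest amount. Compound 4 is therefore expected to give a number near that of compound 1, and the estimated step is a 1.4-fold lower number from compound 1 to compound 4 (0.16 log units; within the scatter). The estimate for compound 4 is 35 ug/mL, within a range from 15 ug/mL to 75 ug/mL.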

Compound 4, half-maximal cytotoxic concentration: 21.8 ug/mL
The estimate for compound 4 lay 1.6-fold (0.21 log units) above the measured number; low and high end bracket the measured number.
By their numbers in this assay, from the lowest: compounds 2, 4, 3 and 1 (each within the scatter of the next, the first and the last beyond it).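

In this assay, the saturated chain carbon bound to an aromatic carbon and a saturated chain carbon proves to be a place where the read-out responds: cyclohexyl in place of butyl gives a 2.3-fold lower number from compound 1 to compound 4 (0.36 log units; beyond the scatter). A change away from the aromatic ring can therefore also move the number beyond the scatter, in the same direction as the chloro step from compound 1, whereas the methoxy step from compound 1 stays within it. No measurement shown here accounts for the step.

The replacement alters both the chain's carbon count and the presence of a ring, so the compounds shown cannot separate the two; a straight hexyl chain or a cyclopentyl group at this place would bear on that. From the compounds shown here alone, it also remains open whether chloro on the aromatic ring would lower the number further when cyclohexyl is present.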